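Ester series: cytotoxicity notes, compound 3 to compound 4

The source may hold more compounds than are shown below. What is called first, only, known or untested is meant among the compounds shown, and "the series" means these compounds.

Measured so far:
- compound 1 `CN(C)c1ccc(-c2cn(-c3ccnc4cc(Cl)ccc34)nn2)cc1`: in an ADME assay on HepG2 cells (Homo sapiens) for cytotoxicity, read by MTT assay, with a stated time of 24 h (a lower number here means that less compound is tolerated, a higher number that more compound is tolerated), compound 1 gives > 2860000 nM, which is a limit of the assay.
- compound 2 `COc1ccc(C(=O)OCCCc2cn(-c3ccnc4cc(Cl)ccc34)nn2)cc1`: in this assay compound 2 gives 347000 nM.
- compound 3 `CCc1ccc(C(=O)OCc2cn(-c3ccnc4cc(Cl)ccc34)nn2)cc1`: in this assay compound 3 gives > 2550000 nM, which is a limit of the assay.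

Compound 3 stands only at a limit, namely (the limit of > 2550000 nM in this assay, at which 1 of the 3 values shown sits). One further value in the set is also a limit, namely (the limit of > 2860000 nM in this assay, at which 1 of the 3 values shown sits). For the measured compounds named here, compound 2 is the only member with a numerical value in this assay. Going by the values given here, no pair of measured compounds differs in one place, so no measured step is available.

Compound 4 `O=C(OCc1cn(-c2ccnc3cc(Cl)ccc23)nn1)c1ccc(C(F)(F)F)cc1` is not yet measured. It differs from compound 3 by trifluoromethyl in place of ethyl on an aromatic carbon; the same difference, cut one bond further out, reads 4-ethylphenyl to 4-(trifluoromethyl)phenyl. Nothing in the measured set reports on such a change, so no direction is supported. The expectation for the step from compound 3 to compound 4 in this assay is an at least 1.0-fold lower number from compound 3 to compound 4 (0.00 log units; that floor lies within the scatter), a step within the scatter. For compound 4 the estimate in this assay is 2500000 nM, within 500000 nM to 5000000 nM, with a fair chance that only a limit is reported again.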

Compound 4, half-maximal cytotoxic concentration: 1070000 nM
Estimate against measurement, compound 4: 2.3-fold (0.37 log units) above; measured number inside the range.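

In this assay, trifluoromethyl in place of ethyl on an aromatic carbon, para to a large group, gives an at least 2.3-fold lower number from compound 3 to compound 4 (0.37 log units; beyond the scatter), the first single-place step available in this set. The substituent at this position can therefore move the read-out beyond the scatter on its own, and the change from 4-ethylphenyl to 4-(trifluoromethyl)phenyl takes the series from a limit to a numerical value. The true size of the step remains unknown because compound 3 stands only at a limit, so the step gives a minimum and not a measured difference: the limit of > 2550000 nM in this assay, at which 1 of the 4 values shown sits.

One pair cannot show whether this shift belongs to trifluoromethyl specifically or would also appear with other replacements for ethyl, such as a nitrile or a carboxylic acid on the same aromatic carbon. Going by these compounds, the separate contribution of the longer chain between the ester and the shared core also stays open, as compound 2 differs from both compound 3 and compound 4 in more than one place.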